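The source may report more compounds than this note shows. Statements on the series, on what has been measured and on what is new or still open speak of the compounds shown alone.

Of the compounds shown here, three sharing one core have numbers so far in a physicochemical assay for lipophilicity; on this read-out higher numbers stand for higher lipophilicity and lower numbers for lower lipophilicity. Compound 1 (`Cc1csc2cc([C@H](C)Nc3ncnc(N)c3C#N)c(-c3cccc(CC4CCN(C(C)C)CC4)c3)c(=O)n12`) gives 1.1, compound 3 (`Cc1csc2cc([C@H](C)Nc3ncnc(N)c3C#N)c(-c3cccc(CN4CCC(N(C)C)CC4)c3)c(=O)n12`) gives 0.5, and compound 2 (`Cc1csc2cc([C@H](C)Nc3ncnc(N)c3C#N)c(-c3cccc(CN(C)CCCN(C)Cc4ccc(Cl)cc4)c3)c(=O)n12`) gives 3.2, the highest of the three and beyond the scatter from both others. Compound 4 (`Cc1csc2cc([C@H](C)Nc3ncnc(N)c3C#N)c(-c3cccc(CN(C)CCCCN4C[C@@H](C)O[C@@H](C)C4)c3)c(=O)n12`) is still unmeasured and differs from compound 2 in one place: (2,6-dimethylmorpholin-4-yl)methyl in place of (4-chlorobenzyl)(methyl)amino on a saturated chain carbon, three bonds along the chain from an amine nitrogen. In words, (2,6-dimethylmorpholin-4-yl)methyl stands in place of (4-chlorobenzyl)(methyl)amino on a saturated chain carbon, three bonds along the chain from an amine nitrogen.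

Going by the values given here, only one measured step bears on this, and only loosely: a number 0.60 log units lower from compound 1 to compound 3 (beyond the scatter), a modest change that swaps 1-isopropylpiperidin-4-yl for 4-(dimethylamino)piperidin-1-yl. Among the compounds with values here, no measured step removes the (4-chlorobenzyl)(methyl)amino group. Within the data shown here, compound 2 is the only measured compound carrying it, while compound 1 at 1.1 and compound 3 at 0.5 lack it and lie well lower, though they also differ elsewhere in that side chain. A downward step beyond the scatter, larger than the modest one, is therefore expected, stopping short of their level. The expected step is a number 1.00 log units lower from compound 2 to compound 4 (beyond the scatter). For compound 4 the estimated value is 2.2, with an expected range of 1.6 to 2.8.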

Compound 4, distribution coefficient: 1.5
For compound 4 the middle estimate is 0.70 log units above the measured one, and the stated range ends above it.
By their numbers in this assay, from the lowest: compound 3; then compound 1; then compound 4; then compound 2.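

In this assay, replacing (4-chlorobenzyl)(methyl)amino with (2,6-dimethylmorpholin-4-yl)methyl on a saturated chain carbon, three bonds along the chain from an amine nitrogen, gives a number 1.70 log units lower from compound 2 to compound 4 (beyond the scatter). Going by these compounds alone, this is the first step at this place, and it is printed as large, whereas a number 0.60 log units lower from compound 1 to compound 3 (beyond the scatter) is printed as modest. The change is not a single feature, since a six-membered aromatic ring of carbon only and the chlorine leave, a six-membered non-aromatic ring with 2 hetero atoms enters, and the same difference also reads as 2-((4-chlorobenzyl)(methyl)amino)ethyl to 3-(2,6-dimethylmorpholin-4-yl)propyl; no measured evidence assigns the step to any one of these features.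

The compounds shown leave open how the step divides among these features, and a benzyl(methyl)amino group without the chlorine, placed on the same chain, would separate the chlorine from the aromatic ring. A plain morpholin-4-yl group on the chain of compound 4 would likewise isolate the contribution of the two methyl groups.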